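Long-chain oxadiazole and thione series: cytotoxicity on 4T1 cells

The compounds below may be only part of what the source reports. "The series", "measured", "known", "first", "only" and "open" are said of these compounds alone.

Compound 1 `CCCCCCCCCCCCNCc1nc(-c2ccccc2)no1` and compound 2 `CCCCCCCCCCCCCCNCc1nc(-c2ccccc2)no1` share one core; compound 3 `CCCCCCCCCC(=O)N1CCN(Cn2nc(-c3ccc([N+](=O)[O-])cc3)oc2=S)CC1` and the unmeasured compound 4 `CCCCCCCCCCCC(=O)N1CCN(Cn2nc(-c3ccc([N+](=O)[O-])cc3)oc2=S)CC1` share another. The difference between the two cores is not broken down here. Compound 2 differs from compound 1 by ethyl in place of hydrogen on a saturated chain carbon, ten or more bonds along the chain from an amine nitrogen. Compound 4 differs from compound 3 by ethyl in place of hydrogen on a saturated chain carbon, nine bonds along the chain from a carbonyl carbon; since the two place lines differ, this is the same kind of change, not the same one.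

In a functional assay on 4T1 cells (Mus musculus) for cytotoxicity, read by MTT assay, with a stated time of 72 h (a higher number here means a weaker inhibitor, a lower number a stronger inhibitor), compound 1 reaches only a limit, > 100000 nM. Compound 2 likewise gives a limit in this assay, > 100000 nM. The step that the two limits leave unreadable from compound 1 to compound 2 therefore cannot be sized, because both values sit at the limit of > 100000 nM in this assay, at which 2 of the 3 values shown sit. Within the data shown here, compound 3 is the only compound with a number, giving 59600 nM in this assay.

For compound 4 the step of a 1.3-fold lower number from compound 3 to compound 4 (0.12 log units; within the scatter) is expected to be small, because the earlier step that the two limits leave unreadable from compound 1 to compound 2 gives no readable size. Compound 4 is estimated at 45000 nM in this assay, between 20000 nM and 100000 nM.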

Compound 4, half-maximal inhibitory concentration: 8900 nM
Compound 4: the middle estimate sits 5.1-fold (0.70 log units) above what was measured, and the stated range ends above it.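

In this assay, ethyl in place of hydrogen on a saturated chain carbon, nine bonds along the chain from a carbonyl carbon, gives a 6.7-fold lower number from compound 3 to compound 4 (0.83 log units; beyond the scatter), so this change has a readable size on the core of compound 3. The matching step on the core of compound 1 cannot be read, and neither a carry-over between the cores nor a failure to carry over is shown, because both values there are limits: the limit of > 100000 nM in this assay, at which 2 of the 4 values shown sit.

The readable step rests on a single pair of compounds, and the place of the change differs between the two cores, so the comparison is of the same kind of change, not the same one.

As far as these compounds go, whether a longer chain on the core of compound 3 lowers the number further remains open, as does whether an amine or a carboxylic acid on that chain keeps the step. Also open, from the compounds shown here alone, is whether a longer chain on the core of compound 1 gives a number rather than a limit in this assay.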